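Swapping the triazole aryl group in a hydroxamic acid series

This account rests on a few compounds, and the source may have more. Where it says the series, first, only, none or still open, it means among the compounds named here.

Measured compounds:
compound 1 `Cc1ccccc1-n1nc(-c2ccccc2)nc1CNc1ccc(C(=O)NO)cc1` — 57.1%
compound 2 `O=C(NO)c1ccc(NCc2nc(-c3cccc4cnccc34)nn2-c2ccccc2)cc1` — 40.2%
compound 3 `O=C(NO)c1ccc(NCc2nc(-c3ccccc3)nn2-c2ccc(F)cc2)cc1` — 67.6%

In an assay on Sf9 cells for inhibition of protein deacetylase HDAC6 (Homo sapiens), read by fluorescence, with a stated time of 40 min, tested at 100 nM (on this read-out lower numbers stand for less inhibition and higher numbers for more inhibition at the one concentration tested (going by the name of the read-out)), the three compounds share one core, and compound 2 stands lowest of the three numbers. Its nearest neighbour is compound 1, whose value lies beyond the scatter above it, and compound 3 lies further still. Within the data shown here, the only step between compounds that differ in one place is a number 10.5 percentage points higher from compound 1 to compound 3 (beyond the scatter); it concerns the group on the aromatic nitrogen, not the position changed here. Compound 4 `O=C(NO)c1ccc(NCc2nc(-c3ccccn3)nn2-c2ccccc2)cc1` differs from compound 2 at the other aryl position: pyridin-2-yl in place of isoquinolin-5-yl on an aromatic carbon.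

Among the measured compounds shown here, no measured step touches this position, so the expectation rests on the values alone. Compounds 1 and 3, which carry phenyl on that carbon, give higher numbers than compound 2, which carries isoquinolin-5-yl. It is therefore estimated that compound 4 moves upward from compound 2, by a number 9.8 percentage points higher from compound 2 to compound 4 (within the scatter), a step of modest size whose direction is the more confident part. Compound 4 is expected to give about 50% in this assay, within a range of 30% to 70%.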

Compound 4, a percentage reported as inhibition, at one concentration (the size of the read-out at that concentration, not a potency): 58.6%
Beside the measured number, compound 4's estimate is 8.6 percentage points below it; the range from low to high includes it.
By their numbers in this assay, from the lowest: compound 2; then compounds 1, 4 and 3 (each within the scatter of the next, the first and the last beyond it).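

Among these compounds, the step of a number 18.4 percentage points higher from compound 2 to compound 4 (beyond the scatter) in this assay is the first measured change at this position, and it shows that the number responds to the aryl group carried on the aromatic carbon between two ring nitrogen atoms. The change removes the six-membered aromatic ring of carbon only and keeps one six-membered aromatic ring with a hetero atom, with no change in the count of hydrogen-bond donors or acceptors and no net charge on either group, so the rise goes with a smaller group of the same counted kind. Nothing available here accounts for this rise.

Since pyridin-2-yl and isoquinolin-5-yl differ both in ring count and in how the group is joined relative to its ring nitrogen, this single step does not separate those two differences, and a plain phenyl group on this carbon with the unsubstituted phenyl on the ring nitrogen would be needed to do so. It also leaves open how the number would respond to a non-aromatic group on this carbon, such as an amine or a carboxylic acid, and whether the step would hold with 4-fluorophenyl on the ring nitrogen.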